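This account rests on a few compounds, and the source may have more. Where it says the series, first, only, none or still open, it means among the compounds named here.

Of the compounds shown here, three built on a shared core have been measured in an ADME assay on BHK-21 cells (Mesocricetus auratus) for cytotoxicity, read by MTT assay, with a stated time of 72 h; on this read-out higher numbers stand for lower toxicity in this test and lower numbers for higher toxicity in this test. Compound 1 `NS(=O)(=O)c1ccc(N2N=C(c3ccc(OCc4ccccc4)cc3)CC2c2ccccc2)cc1` gives 80000 nM, the highest number of the three and so the least toxic reading in this test. Compound 3 `Cc1cccc(C2CC(c3ccccc3)=NN2c2ccc(S(N)(=O)=O)cc2)c1` gives 25000 nM, and compound 2 `NS(=O)(=O)c1ccc(N2N=C(c3ccc(Oc4ccccc4)cc3)CC2c2ccccc2)cc1` gives 11000 nM.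

The unmeasured compound 4 `NS(=O)(=O)c1ccc(N2N=C(c3ccc(OCc4ccccc4)cc3)CC2c2ccccc2F)cc1` keeps all of compound 1 except for one small edit (fluoro in place of hydrogen on an aromatic carbon). This places fluoro in place of hydrogen on an aromatic carbon, ortho to a large group, so that phenyl becomes 2-fluorophenyl.

Going by the values given here, only one measured step changes a single place in the structure, and it is a different kind of change: phenyl in place of benzyl on an oxygen on an aromatic ring. That step, a 7.3-fold lower number from compound 1 to compound 2 (0.86 log units; beyond the scatter), is modest but lies beyond the scatter. Among the compounds with values here, it shows that one edit can move this number, yet it says nothing direct about fluoro, and no measured pair tests that exchange.

With so little to go on, no step beyond the usual scatter is expected, and the estimated step is a 1.1-fold lower number from compound 1 to compound 4 (0.06 log units; within the scatter). For compound 4 the estimated value is 70000 nM, with an expected range from 30000 nM to 150000 nM.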

Compound 4, half-maximal cytotoxic concentration: 90000 nM
The estimate for compound 4 lay 1.3-fold (0.11 log units) below the measured number; measured number inside the range.
By their numbers in this assay, from the lowest: compound 2; then compound 3; then compounds 1 and 4 (each within the scatter of the next).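

Placing fluoro in place of hydrogen on an aromatic carbon, ortho to a large group, gives a 1.1-fold higher number from compound 1 to compound 4 (0.05 log units; within the scatter) in this assay. Going by these compounds alone, this is the first measured exchange on this phenyl, and it shows that turning phenyl into 2-fluorophenyl leaves the reading indistinguishable from that of compound 1, at least when the benzyl on the oxygen stays in place. The single edit elsewhere in the structure, a 7.3-fold lower number from compound 1 to compound 2 (0.86 log units; beyond the scatter), lies beyond the scatter, so not every single change in this series leaves the number in place, though no information bears on why this one makes no measurable difference.

On these data alone, one fluoro at one place cannot show how this ring responds to other groups, so it remains open whether a chloro, a methoxy, an amine or a carboxylic acid at the same spot would also leave the number within the scatter. As far as these compounds go, it is also open whether fluoro would give the same result with the phenyl on the oxygen of compound 2 in place of the benzyl of compound 1.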